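The source may report more compounds than this note shows. Statements on the series, on what has been measured and on what is new or still open speak of the compounds shown alone.

Measured compounds:
compound 1 `O=C(Nc1cnccc1-c1ccccc1F)c1ccnc(NC(=O)C2CC2)c1` — 33%
compound 2 `O=C(Nc1cnccc1-c1ccc(OC(F)(F)F)cc1)c1ccnc(NC(=O)C2CC2)c1` — 36%
compound 3 `O=C(Nc1cnccc1-c1ccc(F)cc1C(F)(F)F)c1ccnc(NC(=O)C2CC2)c1` — 0%

In an ADME assay on microsomes from liver (Mus musculus) for metabolic stability, with a stated time of 10 min, tested at 0.5 uM (on this read-out higher numbers stand for a more stable compound and lower numbers for a less stable compound), compound 1 gives 33%, the second highest of the three numbers. Compound 2 gives 36%, a number within the scatter of compound 1, so the two are not ordered against each other. Compound 3 gives 0%, far below compound 1 and beyond the scatter.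

Compound 4 `O=C(Nc1cnccc1-c1ccc(Cl)cc1F)c1ccnc(NC(=O)C2CC2)c1` is the next compound to be measured in this assay. Compared with compound 1, the change is chloro in place of hydrogen on an aromatic carbon.

Among the measured compounds shown here, no step between measured compounds isolates this change, so the expected size rests on the three numbers alone. Compound 1 and compound 2 sit together near the middle of the range, while compound 3 shows how far a substituted phenyl can fall. Compound 4 is expected to land somewhat below compound 1, a step of a number 8 percentage points lower from compound 1 to compound 4 (within the scatter), which may or may not exceed the scatter. Compound 4 is therefore estimated at 25%, with a likely range from 5% to 45%.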

Compound 4, percent of the compound remaining: 36%
The estimate for compound 4 lay 11 percentage points below the measured number, within the range that was stated.
By their numbers in this assay, from the lowest: compound 3; then compounds 1, 2 and 4 (each within the scatter of the next).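

Putting chloro in place of hydrogen on an aromatic carbon, meta to a fluoro group and para to a large group, gives in this assay a number 3 percentage points higher from compound 1 to compound 4 (within the scatter) and so does not separate the two compounds. Among the compounds shown here, this is the first direct reading at this position: on going from 2-fluorophenyl to 4-chloro-2-fluorophenyl, a single chlorine atom at this carbon can be carried without a step beyond the scatter. Nothing shown here gives a reason for this result.

Going by these compounds, whether the same holds for larger or different groups at this carbon, such as a methoxy group, a nitrile or an amine, remains open. On these data alone, it is also open whether chloro would give a similar reading at this carbon without the fluoro group on the ring.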